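A few compounds are considered here, and "the series" means these few. Any claim that something is new, unique, unknown or untested is made for them only; others in the source may bear on it.

Measured compounds:
Compound 1 `O=C(NCc1ccc(CNS(=O)(=O)c2ccccc2)cc1)c1ccc([N+](=O)[O-])cc1`: 100 nM
Compound 2 `Cc1ccc(S(=O)(=O)NCc2ccc(CNC(=O)c3ccncc3)cc2)cc1`: 10 nM
Compound 3 `Cc1ccc(C(=O)NCc2ccc(CNS(=O)(=O)c3ccc(C)cc3)cc2)cc1`: 1000 nM

In an assay on MDA-MB-231 cells for binding affinity to C-X-C chemokine receptor type 4 (Homo sapiens), read by immunofluorescence and microscopy, with stated times of 10 min and 30 min (a lower number here means that less compound is needed, a higher number that more compound is needed for the effect), compound 3 gives the highest of the three numbers, so the most compound is needed for the effect. Compound 1 sits a step lower, and compound 2 lower still; the step of a 100-fold higher number from compound 2 to compound 3 (2.00 log units; beyond the scatter) shows how much the number rose when the pyridin-4-yl group on the carbonyl carbon was exchanged for 4-methylphenyl.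

Compound 4 `Cc1ccc(S(=O)(=O)NCc2ccc(CNC(=O)c3ccccc3)cc2)cc1` differs from compound 3 in one place: hydrogen in place of methyl on an aromatic carbon. The methyl group is taken off the benzoyl ring, leaving a plain phenyl on the carbonyl carbon.

Within the data shown here, no measured step covers this exact change. Among the measured compounds shown here, the only step that touches the same part of the molecule, from compound 2 to compound 3, concerns a different exchange on the carbonyl carbon and is large, which says only that the amide aryl group matters to this assay. Since compound 4 keeps a six-membered carbon ring there, the expectation is a modest move toward a lower number from compound 3, of roughly a 2.0-fold lower number from compound 3 to compound 4 (0.30 log units; within the scatter), with wide uncertainty. Compound 4 is therefore estimated at 500 nM, within a range from 100 nM to 3000 nM.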

Compound 4, effective concentration (reported as EC, without a stated level of effect): > 1000 nM
Compound 4 ended at the assay's limit; the forecaster's own chance of this, stated with the estimate: 5%; at least 2.0-fold (0.30 log units) between middle value and limit.
By their numbers in this assay, from the lowest: compound 2; then compound 1; then compound 3.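

In this assay compound 4 stops at a limit of the assay rather than at a number, > 1000 nM, and the reading sits at the edge of what can be reported here: the limit of > 1000 nM in this assay, at which 1 of the 4 values shown sits.

Taking the methyl group off the ring gives a number no lower from compound 3 to compound 4 (the limit leaves the size open) and so cannot be read for size, but it does show that this change did not bring the number down, so a plain phenyl on the carbonyl carbon offers no recovery toward the low end of the series. The step from pyridin-4-yl to phenyl is also large, an at least 100-fold higher number from compound 2 to compound 4 (2.00 log units; beyond the scatter), so the wide gap first seen with 4-methylphenyl is now seen with a second six-membered carbon ring, and it does not depend on the methyl group being present.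

The compounds shown leave open how far past the limit compound 4 lies, and so whether removing the methyl group changes anything at all. They also leave open what an amine, a carboxylic acid or a longer chain such as ethyl would do at this same place on the ring.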